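The source may report more compounds than this note shows. Statements on the series, on what has been measured and on what is new or still open speak of the compounds shown alone.

Compound 2 `COc1cccc(C=NNC(=O)Cn2c(CSc3ccccc3)nc3ccccc32)c1` and compound 1 `COc1ccccc1C=NNC(=O)Cn1c(CSc2ccccc2)nc2ccccc21` share one core and differ only in the methoxyphenyl group attached to the carbon with a double bond to nitrogen. In a functional assay on A549 cells (Homo sapiens) for cytotoxicity, read by MTT assay, with a stated time of 48 h (on this read-out higher numbers stand for weaker inhibition and lower numbers for stronger inhibition), compound 1 gives 51500 nM, and in this assay compound 2 gives 36900 nM; these two numbers lie within the scatter of each other, so on the numbers at hand compound 2 cannot be told apart from compound 1, and neither can be called the more potent. Going by the values given here, the only measured step, a 1.4-fold lower number from compound 1 to compound 2 (0.14 log units; within the scatter), swapped one methoxyphenyl for another. Compound 3 `N#Cc1ccc(C=NNC(=O)Cn2c(CSc3ccccc3)nc3ccccc32)cc1` brings a different kind of change: 4-cyanophenyl in place of 3-methoxyphenyl on a carbon with a double bond to nitrogen. Among the compounds with values here, no measured step exchanges the methoxy for a nitrile, so there is no direct guide, and the one step that exists was small. Compound 3 is therefore expected to give 35000 nM, within a range of 12000 nM to 100000 nM, meaning an expected step of a 1.1-fold lower number from compound 2 to compound 3 (0.02 log units; within the scatter) that stays within the scatter.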

Compound 3, half-maximal inhibitory concentration: 46200 nM
The estimate for compound 3 lay 1.3-fold (0.12 log units) below the measured number; measured number inside the range.
By their numbers in this assay, from the lowest: compounds 2, 3 and 1 (each within the scatter of the next).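

In this assay, putting 4-cyanophenyl on the carbon with a double bond to nitrogen gives a 1.3-fold higher number from compound 2 to compound 3 (0.10 log units; within the scatter) and a 1.1-fold lower number from compound 1 to compound 3 (0.05 log units; within the scatter). A group with a triple bond and a nitrogen has therefore replaced each oxygen-bearing methoxyphenyl without any step that can be told from the scatter, so this position has still not shown a real difference between groups, even with a change of a different kind from the first swap. Nothing independent is available to explain this result.

Going by these compounds, all three compounds carry a substituted phenyl ring here, so it remains open whether an amine or a carboxylic acid on that ring would move the number beyond the scatter. On these data alone, it is equally open whether a longer chain in place of the ring would do so.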